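Closing the Amine Chain into a Ring: Compound 2 to Compound 3

This account rests on a few compounds, and the source may have more. Where it says the series, first, only, none or still open, it means among the compounds named here.

Of the compounds shown here, two have so far been measured in an assay for inhibition of acid-sensing ion channel 3 (Homo sapiens), read by patch clamp, tested at 20 uM; a higher number here means more inhibition at the concentration tested (going by the name of the read-out), a lower number less inhibition. Compound 1 `NC(N)=NC(=O)c1nc(Cl)c(NC2CC2)nc1N` gives 78%. Compound 2 `CCCN(C)c1nc(N)c(C(=O)N=C(N)N)nc1Cl` gives 91%, the higher of the two numbers shown; the only other number, that of compound 1, lies beyond the scatter below it. Going by the values given here, the one measured step, a number 13 percentage points higher from compound 1 to compound 2 (beyond the scatter), came with methyl(propyl)amino in place of cyclopropylamino on an aromatic carbon, a modest gain.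

Compound 3 `NC(N)=NC(=O)c1nc(Cl)c(N2CCCC2)nc1N` has not yet been measured. It differs from compound 2 in one place: pyrrolidin-1-yl in place of methyl(propyl)amino on an aromatic carbon. The group that leaves and the group that enters have the same count of heavy atoms, and both are amines attached to the same aromatic carbon. Among the compounds with values here, the only measured step that bears on this place is a number 13 percentage points higher from compound 1 to compound 2 (beyond the scatter), and it was modest even though it exchanged one amine for another of a different shape. The step of a number 3 percentage points lower from compound 2 to compound 3 (within the scatter) is therefore expected to stay within the scatter, with no clear direction. Compound 3 is estimated at 88%, with a range from 74% to 98%.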

Compound 3, a percentage reported as inhibition, at one concentration (the size of the read-out at that concentration, not a potency): 84%
The estimate for compound 3 lay 4 percentage points above the measured number, and the stated range covers the measured number.
By their numbers in this assay, from the lowest: compounds 1, 3 and 2 (each within the scatter of the next, the first and the last beyond it).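

In this assay, closing the open methyl(propyl)amino chain into a pyrrolidin-1-yl ring, with the same count of heavy atoms, gave a number 7 percentage points lower from compound 2 to compound 3 (within the scatter) and so shows no clear effect of the ring at this position. The second comparison gave a number 6 percentage points higher from compound 1 to compound 3 (within the scatter) for pyrrolidin-1-yl against cyclopropylamino, so compound 3 cannot be separated from either neighbor, although compound 1 and compound 2 do lie apart beyond the scatter; the three amines therefore give no simple ranking based on ring or chain. No measurement available here offers an explanation for how closely these amines match.

The compounds shown leave open whether a larger ring such as piperidin-1-yl or morpholin-4-yl, or a longer chain such as dipropylamino, would keep inhibition at this level. They also leave open whether an amine is needed on this aromatic carbon at all, a question that a methoxy group or a plain hydrogen in its place could begin to answer.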